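Vinyl sulfinyl analogue of an alpha-ketooxazole FAAH inhibitor

A few compounds are considered here, and "the series" means these few. Any claim that something is new, unique, unknown or untested is made for them only; others in the source may bear on it.

Measured compounds:
compound 1, `O=C(CCCCCCc1ccccc1)c1ncc(-c2ccc(CCl)cn2)o1`, 20.1 nM
compound 2, `CCOS(=O)(=O)/C=C/c1ccc(-c2cnc(C(=O)CCCCCCc3ccccc3)o2)nc1`, 0.3 nM

In an assay for inhibition of Fatty-acid amide hydrolase 1 (Rattus norvegicus), using a Dixon plot, with a stated time of 3 h (a lower number here means a stronger inhibitor, a higher number a weaker inhibitor), compound 2 gives 0.3 nM, the lowest of the two numbers measured; its nearest neighbour is compound 1, which in this assay gives 20.1 nM. Going by the values given here, the only measured step at this position is a 67-fold lower number from compound 1 to compound 2 (1.83 log units; beyond the scatter). Compound 3, `C[S+]([O-])/C=C/c1ccc(-c2cnc(C(=O)CCCCCCc3ccccc3)o2)nc1`, is not yet measured; it differs from compound 2 by a group of 3 heavy atoms (1 carbon, 1 oxygen, 1 sulfur; no ring) in place of a group of 6 heavy atoms (2 carbon, 3 oxygen, 1 sulfur; no ring), on a double-bonded chain carbon bound to a double-bonded chain carbon. Among the compounds with values here, no measured step involves the entering group, so the size of this change is not known from the data. Because the step of a 67-fold lower number from compound 1 to compound 2 (1.83 log units; beyond the scatter) shows that the group at this position moves this assay strongly, and compound 3 carries a smaller group than compound 2, the number is expected to rise by a 13-fold higher number from compound 2 to compound 3 (1.12 log units; beyond the scatter). Compound 3 is therefore estimated at 4 nM in this assay, within a range of 0.6 nM to 25 nM.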

Compound 3, inhibition constant: 1 nM
Compound 3: the middle estimate sits 4.0-fold (0.60 log units) above what was measured; measured number inside the range.
By their numbers in this assay, from the lowest: compound 2; then compound 3; then compound 1.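

In this assay the ethoxysulfonyl group can give way to the much smaller group of 3 heavy atoms at modest cost, with a 3.3-fold higher number from compound 2 to compound 3 (0.52 log units; beyond the scatter) as the price of the exchange on the double-bonded chain carbon. Most of the gain over the chloromethyl group of compound 1 survives, as a 20-fold lower number from compound 1 to compound 3 (1.30 log units; beyond the scatter) shows, so the full ethoxysulfonyl group is not required for a low number, even though compound 2 remains the lowest of the three. Nothing available explains why these two sulfur-bearing groups differ.

The compounds shown leave open whether a nitrile, an amide or a carboxylic acid on the same double-bonded chain carbon would serve as well as a sulfur-bearing group. They also do not tell how a saturated chain in place of the double bond would compare.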